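Working notes: methoxy for fluoro, compound 2 to compound 4

This account rests on a few compounds, and the source may have more. Where it says the series, first, only, none or still open, it means among the compounds named here.

Measured in an ADME assay on SH-SY5Y cells (Homo sapiens) for cytotoxicity, read by MTT assay, with a stated time of 72 h; a higher number here means a weaker inhibitor, a lower number a stronger inhibitor:
Compound 1 `O=C(CN1CCN(C(=O)c2ccc(Cl)cc2)CC1)N1CCN(CCCc2c[nH]c3ccc(F)cc23)CC1`: 125000 nM
Compound 2 `Cc1ccc(C(=O)N2CCN(CC(=O)N3CCN(CCCc4c[nH]c5ccc(F)cc45)CC3)CC2)cc1`: 119000 nM
Compound 3 `O=C(CN1CCN(C(=O)c2cccc(Br)c2)CC1)N1CCN(CCCc2c[nH]c3ccc(F)cc23)CC1`: 71600 nM

Compound 2 is not separated from the other two compounds. The measurements show a 1.1-fold lower number from compound 1 to compound 2 (0.02 log units; within the scatter) and a 1.7-fold lower number from compound 2 to compound 3 (0.22 log units; within the scatter), and the remaining pair shows a 1.7-fold lower number from compound 1 to compound 3 (0.24 log units; within the scatter). The three compounds therefore form one group, with no order among them.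

The next compound is compound 4 `COc1ccc2[nH]cc(CCCN3CCN(C(=O)CN4CCN(C(=O)c5ccc(C)cc5)CC4)CC3)c2c1`, which differs from compound 2 as follows: methoxy in place of fluoro on an aromatic carbon. In words, this is methoxy in place of fluoro on an aromatic carbon, with 5-fluoro-1H-indol-3-yl becoming 5-methoxy-1H-indol-3-yl.

For the measured compounds named here, no measured step touches this place, so the data lack a direct fluoro-to-methoxy comparison. All three steps change the aryl group on a carbonyl carbon and bear on the question only indirectly. The closest in kind is a 1.1-fold lower number from compound 1 to compound 2 (0.02 log units; within the scatter), also a swap of one group for another on an aromatic carbon. Going by the values given here, no step so far leaves the scatter, so no shift beyond it is expected in this assay, and no direction is favoured. The expected step is a 1.1-fold lower number from compound 2 to compound 4 (0.05 log units; within the scatter). Taking compound 2 at 119000 nM as the anchor, the estimate for compound 4 is 105000 nM, with an expected range from 45000 nM to 240000 nM.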

Compound 4, half-maximal inhibitory concentration: > 200000 nM
Compound 4: only a limit was reported; the forecaster's own chance of this, stated with the estimate: 10%; middle value at least 1.9-fold (0.27 log units) from the limit.
By their numbers in this assay, from the lowest: compounds 3, 2 and 1 (each within the scatter of the next). At a limit, above all of these: compound 4.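

Methoxy in place of fluoro on an aromatic carbon is the first change read at this place, since compound 1, compound 2 and compound 3 all carry 5-fluoro-1H-indol-3-yl and differ only in the aryl group on the carbonyl carbon. In this assay compound 4 gives > 200000 nM, which is a limit and not a number. Read as a floor and not as a size, the step is an at least 1.6-fold higher number from compound 2 to compound 4 (0.22 log units; that floor lies within the scatter), so this change gives no lower number in compound 4, and the reading ends at a limit: the limit of > 200000 nM in this assay, at which 1 of the 4 values shown sits.

On these data alone, the true size of the step stays open, as does whether any group at this aromatic carbon can move the number beyond the scatter; hydroxy, chloro, nitrile or a bare hydrogen there would test this. The compounds shown also leave open whether 5-methoxy-1H-indol-3-yl gives the same reading when paired with the 4-chlorophenyl of compound 1 or the 3-bromophenyl of compound 3, as the methoxy change is seen only against the 4-methylphenyl of compound 2.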